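This account rests on a few compounds, and the source may have more. Where it says the series, first, only, none or still open, it means among the compounds named here.

Measured in a functional assay on MCF7 cells (Homo sapiens) for inhibition, read by MTT assay, with a stated time of 48 h; a higher number here means a weaker inhibitor, a lower number a stronger inhibitor:
compound 1 `c1ccc(-c2nn(-c3ccccc3)c3nccc(-c4cccs4)c23)cc1`: 39300 nM
compound 2 `CN1CCN(c2ccc(-c3c(C#N)c(-c4ccc(Cl)cc4)nc4c3c(-c3ccccc3)nn4-c3ccccc3)cc2)CC1`: 2710 nM

Compound 1 holds the higher of the two numbers, and its gap to compound 2 lies beyond the scatter. Within the data shown here, no measured pair differs in one place only, so the series offers no direct guide to single changes. Compound 3 `Fc1ccc(-c2ccnc3c2c(-c2ccccc2)nn3-c2ccccc2)cc1` carries 4-fluorophenyl in place of thiophen-2-yl on an aromatic carbon, opposite the ring nitrogen: 4-fluorophenyl in place of thiophen-2-yl on an aromatic carbon. The expected change in this assay stays within the scatter: a 1.3-fold lower number from compound 1 to compound 3 (0.12 log units; within the scatter). Compound 3 is estimated at 30000 nM, with an expected range of 11000 nM to 75000 nM.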

Compound 3, half-maximal inhibitory concentration: 1570 nM
The estimate for compound 3 lay 19-fold (1.28 log units) above the measured number; measured number below the stated range.
By their numbers in this assay, from the lowest: compounds 3 and 2 (each within the scatter of the next); then compound 1.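

In this assay the change to 4-fluorophenyl in place of thiophen-2-yl is a 25-fold lower number from compound 1 to compound 3 (1.40 log units; beyond the scatter) on an aromatic carbon, opposite the ring nitrogen. This gives the series its first single-place comparison and shows that the group at this position can shift the number well beyond the scatter. No available evidence accounts for the size of this step. As far as these compounds go, whether the fluorine or the six-membered ring carries the change remains open, as does the outcome with unsubstituted phenyl or an amine such as piperidine here.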